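A few compounds are considered here, and "the series" means these few. Any claim that something is new, unique, unknown or untested is made for them only; others in the source may bear on it.

Compound 1 `O=C1c2ccc(OCc3cccc(-c4ccccc4)c3)cc2CN1C1CCCC1`: in an assay on HEK293 cells for positive allosteric modulation of metabotropic glutamate receptor 2 (Rattus norvegicus), read by thallium flux (on this read-out higher numbers stand for an effect only at larger amounts of compound and lower numbers for an effect already at smaller amounts), compound 1 gives > 5000 nM, a limit of the assay and not a number.
Compound 2 `O=C(O)c1ccc(Cl)c(-c2cccc(COc3ccc4c(c3)CN(C3CCCC3)C4=O)c2)c1`: compound 2 gives 90 nM.
Compound 3 `COc1ccc(-c2cccc(COc3ccc4c(c3)CN(C3CCCC3)C4=O)c2)cc1C(=O)O`: compound 3 gives 170 nM.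

Compound 3 and compound 2 lie within the scatter of each other (a 1.9-fold higher number from compound 2 to compound 3 (0.28 log units; within the scatter)); for compound 1 only the limit is known (the limit of > 5000 nM in this assay, at which 1 of the 3 values shown sits).

Compound 4 `O=C(O)c1cc(F)cc(-c2cccc(COc3ccc4c(c3)CN(C3CCCC3)C4=O)c2)c1` differs from compound 3 in one place: 3-carboxy-5-fluorophenyl in place of 3-carboxy-4-methoxyphenyl on an aromatic carbon.

The measured steps that bear on this are an at least 55-fold lower number from compound 1 to compound 2 (1.74 log units; beyond the scatter) and an at least 29-fold lower number from compound 1 to compound 3 (1.46 log units; beyond the scatter), both large, and a 1.9-fold higher number from compound 2 to compound 3 (0.28 log units; within the scatter), within the scatter. Compound 4 keeps a carboxyphenyl group, so no step beyond the scatter is expected. Compound 4 is therefore estimated at 150 nM, between 60 nM and 400 nM. The estimate means a step of a 1.1-fold lower number from compound 3 to compound 4 (0.05 log units; within the scatter), expected to stay within the scatter.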

Compound 4, half-maximal effective concentration: 130 nM
Compound 4: the middle estimate sits 1.2-fold (0.06 log units) above what was measured; measured number inside the range.
By their numbers in this assay, from the lowest: compounds 2, 4 and 3 (each within the scatter of the next). At a limit, above all of these: compound 1.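

With 3-carboxy-5-fluorophenyl on this aromatic carbon, a third carboxyphenyl group reads alike within the scatter, with fluorine carried in place of the methoxy or chlorine of the earlier two: a 1.3-fold lower number from compound 3 to compound 4 (0.12 log units; within the scatter) and a 1.4-fold higher number from compound 2 to compound 4 (0.16 log units; within the scatter). The large step from the plain phenyl also holds for this group, an at least 38-fold lower number from compound 1 to compound 4 (1.58 log units; beyond the scatter). That step rests on a limit and not a number for compound 1: the limit of > 5000 nM in this assay, at which 1 of the 4 values shown sits. Open, as far as these compounds go, is whether a methyl ester, a primary amide or a tetrazole can replace the carboxylic acid, and how an unsubstituted 3-carboxyphenyl reads.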